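Dropping a methoxy from the ether side chain

This account rests on a few compounds, and the source may have more. Where it says the series, first, only, none or still open, it means among the compounds named here.

Compound 2 `CCC(COC)Oc1nc(C)nc2c1nnn2-c1ccc(C(C)C)cc1Br` gives the lowest of the two numbers in an in vitro assay on 293-EBNA cells for binding affinity to corticotropin-releasing factor receptor 1 (Homo sapiens) (a higher number here means a weaker inhibitor, a lower number a stronger inhibitor), with compound 2 at 1.9 nM; compound 1 `COCC(COC)N(C)c1nc(C)nc2c1nnn2-c1ccc(C(C)C)cc1Br` gives 21.3 nM, and the change an 11-fold lower number from compound 1 to compound 2 (1.05 log units; beyond the scatter) is large. Compound 3 `CCC(CC)Oc1nc(C)nc2c1nnn2-c1ccc(C(C)C)cc1Br` differs from compound 2 by methyl in place of methoxy on a saturated chain carbon, two bonds along the chain from an oxygen on an aromatic ring. Among the compounds with values here, no measured step touches this chain position, so the only guide is that the ether series sits at the strong end. Compound 3 is therefore expected to give 2.5 nM, between 0.8 nM and 8 nM, a step of a 1.3-fold higher number from compound 2 to compound 3 (0.12 log units; within the scatter) that stays within the scatter.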

Compound 3, inhibition constant: 1.9 nM
Estimate against measurement, compound 3: 1.3-fold (0.12 log units) above; low and high end bracket the measured number.
By their numbers in this assay, from the lowest: compounds 2 and 3 (each within the scatter of the next); then compound 1.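

In this assay, the methoxy on this saturated chain carbon can give way to methyl with no change at the digits printed from compound 2 to compound 3 (within the scatter), so the pentan-3-yl ether serves as well as the 1-(methoxymethyl)propyl ether. That ether also keeps the large distance from the side chain of compound 1, with an 11-fold lower number from compound 1 to compound 3 (1.05 log units; beyond the scatter). No evidence at hand accounts for either step.

Going by these compounds, whether a longer chain, such as propyl, or a hydroxyl at this chain carbon would hold the number stays open.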